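Chain length at the aromatic carbon of the urea series

This account rests on a few compounds, and the source may have more. Where it says the series, first, only, none or still open, it means among the compounds named here.

Measured so far:
compound 1, `CCCc1ccc(NC(=O)N[C@H](C)c2ccccc2)cc1`, 33%
compound 2, `C[C@@H](NC(=O)Nc1ccc(C(C)(C)C)cc1)c1ccccc1`, 100%
compound 3, `CCCCCCc1ccc(NC(=O)N[C@H](C)c2ccccc2)cc1`, 100%

Three ureas have been run in an ADME assay on the whole organism with Oryza sativa as the target, tested at 0.1 uM; on this read-out higher numbers stand for a weaker effect at the one concentration tested and lower numbers for a stronger effect. Compound 1 gives 33%, the lowest of the three numbers. Compound 2 gives 100%, and compound 3 gives 100%; these two are level at the digits printed and together stand highest. The step of a number 67 percentage points higher from compound 1 to compound 3 (beyond the scatter) shows that lengthening the chain on the aromatic carbon carries the number to the top of the range, while the step of no change at the digits printed from compound 2 to compound 3 (within the scatter) shows that trading tert-butyl for hexyl leaves it where it was.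

Compound 4, `CCCCCCCc1ccc(NC(=O)N[C@H](C)c2ccccc2)cc1`, extends the chain by one more carbon: methyl in place of hydrogen on a saturated chain carbon, six bonds along the chain from an aromatic carbon.

The two steps that bear on this change point the same way. Once the chain is long, further alteration at the aromatic carbon has given no movement beyond the scatter, so for compound 4 no step beyond the scatter is expected in this assay. The estimated step is a number 2 percentage points lower from compound 3 to compound 4 (within the scatter), resting on the flat step no change at the digits printed from compound 2 to compound 3 (within the scatter). Compound 4 is therefore expected to give about 98%, within 85% to 105%.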

Compound 4, a percentage reported as activity, at one concentration (the size of the read-out at that concentration, not a potency): 100%
For compound 4 the middle estimate is 2 percentage points below the measured one; measured number inside the range.
By their numbers in this assay, from the lowest: compound 1; then compounds 2, 3 and 4 (each within the scatter of the next).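

In this assay, methyl in place of hydrogen on a saturated chain carbon, six bonds along the chain from an aromatic carbon, gives no change at the digits printed from compound 3 to compound 4 (within the scatter), so the series now shows that hexyl and heptyl at this aromatic carbon are not told apart by this read-out. Heptyl also stands with tert-butyl, at no change at the digits printed from compound 2 to compound 4 (within the scatter), while the step of a number 67 percentage points higher from compound 1 to compound 4 (beyond the scatter) sets it apart from propyl, so that among these four ureas only compound 1 stands away from the others, and a second long chain now confirms what hexyl alone could only suggest. No measurement in hand offers an explanation for this division between propyl and the other three groups.

The compounds shown leave open where between propyl and hexyl the number moves, a question that a butyl or pentyl chain at the aromatic carbon would address. They also leave open whether an ethyl group, a shorter chain than that of compound 1, or a propyl chain ending in a hydroxyl or an amine, would fall on the side of compound 1 at 33% or with the other three.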